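The compounds below may be only part of what the source reports. "The series", "measured", "known", "first", "only" and "open" are said of these compounds alone.

Series notes. Compound 1 `COc1ccc(-n2cnc3cnc(-c4ccc(F)cc4C)cc32)cc1OC`, compound 2 `COc1ccc(-n2cnc3cnc(-c4ccc(F)cc4OC)cc32)cc1OC` and compound 3 `COc1ccc(-n2cnc3cnc(-c4cc(F)ccc4C)cc32)cc1OC` share one core and have been run in an ADME assay on S9 fraction from liver (Mus musculus) for metabolic stability, read by LC-MS, using NADPH, with a stated time of 45 min, tested at 3 uM, in the presence of a further agent that is not named here; on this read-out lower numbers stand for lower hepatic extraction and higher numbers for higher hepatic extraction. In this assay compound 1 gives 1, compound 2 gives 1 and compound 3 gives 1. The change from compound 1 to compound 2 is methoxy in place of methyl on an aromatic carbon; the step it made was no change at the digits printed from compound 1 to compound 2 (within the scatter). The change from compound 1 to compound 3 is 5-fluoro-2-methylphenyl in place of 4-fluoro-2-methylphenyl on an aromatic carbon, with no change at the digits printed from compound 1 to compound 3 (within the scatter); for compound 2 to compound 3 the step reads no change at the digits printed from compound 2 to compound 3 (within the scatter).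

Compound 4 `COc1ccc(-n2cnc3cnc(-c4cc(F)ccc4OC)cc32)cc1OC` is not yet measured. It differs from compound 3 by methoxy in place of methyl on an aromatic carbon. This is the same kind of change as that from compound 1 to compound 2, but the place is not the same: in compound 1 to compound 2 the site is meta to a fluoro group, whereas in compound 3 to compound 4 it is para to a fluoro group. The step from compound 3 to compound 4 in this assay is expected to be a number 0.020 lower from compound 3 to compound 4 (within the scatter), beside the earlier one, which rests on no change at the digits printed from compound 1 to compound 2 (within the scatter) and on compound 3 standing at 1. Compound 4 is therefore estimated at 0.98, between 0.9 and 1.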

Compound 4, hepatic extraction ratio: 1
Compound 4: the middle estimate sits 0.020 below what was measured; the measured number falls inside the stated range.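

In this assay, methoxy in place of methyl on the core of compound 3 gives no change at the digits printed from compound 3 to compound 4 (within the scatter), while the other two new steps read no change at the digits printed from compound 2 to compound 4 (within the scatter) and no change at the digits printed from compound 1 to compound 4 (within the scatter). Set beside the earlier step, the same change reads alike on both cores: the same change on two cores in this assay, no change at the digits printed (within the scatter) from compound 1 to compound 2 and no change at the digits printed (within the scatter) from compound 3 to compound 4, 0 apart, within the scatter of two such steps. Among these compounds, this shows that the change carries across these two pairs without a step that can be read in this assay, but all four compounds print the same value, so no step of any size has been carried over and the result does not show that the change would stay silent on another core.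

The compounds shown leave open whether any group at this place can move the hepatic extraction ratio from this shared value, for instance an amine, a carboxylic acid or a longer chain in place of the methyl or methoxy group. They also leave open what a change on the dimethoxyphenyl part would do, since those two methoxy groups are the same in all four compounds.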